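Enlarging a Ring on a Weak Calcium Channel Binder

The compounds below may be only part of what the source reports. "The series", "measured", "known", "first", "only" and "open" are said of these compounds alone.

Compound 1 `c1ccc(C(CCNC2=NCCCN2)c2ccccc2)cc1` was tested in an assay on cell membranes with Voltage-dependent L-type calcium channel subunit alpha-1C (Rattus norvegicus) as the target; on this read-out higher numbers stand for weaker inhibition and lower numbers for stronger inhibition. In this assay compound 1 gives > 1000 nM, which is a limit of the assay rather than a number. Compound 2 `CN1CCN=C1NCCCC(c1ccccc1)c1ccccc1` likewise reaches only a limit, giving > 1000 nM in this assay. Both sit at the limit of > 1000 nM in this assay, at which 2 of the 2 values shown sit, so neither can be ranked against the other. Compound 3 `c1ccc(C(CCN/C2=N/CCCCCN2)c2ccccc2)cc1` differs from compound 1 by a group of 8 heavy atoms (6 carbon, 2 nitrogen; one eight-membered non-aromatic ring with 2 hetero atoms) in place of a group of 6 heavy atoms (4 carbon, 2 nitrogen; one six-membered non-aromatic ring with 2 hetero atoms), on an amine nitrogen. Within the data shown here, no measured pair shows such a change, so no step beyond the scatter is expected. The expected step from compound 1 to compound 3 is a step that the limit leaves unreadable from compound 1 to compound 3. Compound 3 is estimated at 2500 nM, between 800 nM and 8000 nM.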

Compound 3, half-maximal inhibitory concentration: > 1000 nM
Compound 3: only a limit was reported; the forecaster's own chance of this, stated with the estimate: 75%; the middle value lies beyond the limit too.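

Among these compounds, compound 1 and compound 3 both give only a limit, and no step between them can be read. As far as these compounds go, how the eight-membered ring compares with the six-membered ring in strength of binding stays open.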